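A few compounds are considered here, and "the series" means these few. Any claim that something is new, unique, unknown or untested is made for them only; others in the source may bear on it.

Working notes on the series. Compound 2 `Cc1cccc(C)c1NC(=O)[C@H](N)CC(C)C` gives 6.6 mg/kg in a functional assay on the whole organism (strain Swiss Albino) with Mus musculus as the target; a higher number here means that more compound is needed for the effect, a lower number that less compound is needed; on the two numbers available it stands at the higher end, with compound 1 `Cc1cccc(C)c1NC(=O)[C@H](N)C(C)C` nearest, and compound 1 gives 5.7 mg/kg. For the measured compounds named here, the single measured step, a 1.2-fold higher number from compound 1 to compound 2 (0.06 log units; within the scatter), is a side-chain change and lies within the scatter.

Compound 3 `Cc1cccc(C)c1NC(=O)[C@@H](N)CC(C)C` is the next entry. It differs from compound 2 only in configuration: the two compounds have the same atoms and bonds and differ only in configuration as drawn: 1 of 1 stereo elements differ; a stereocentre at a saturated chain carbon is drawn R in compound 2 and S in compound 3. Going by the values given here, no measured step involves an inversion at this stereocentre, so the step from compound 1 to compound 2 does not bear on it, and its size gives no guide. The expectation is therefore unanchored: compound 3 could match compound 2, or could depart from it in either direction beyond the scatter. As a working estimate, compound 3 is expected at 8 mg/kg (range 3 mg/kg to 25 mg/kg), a step of a 1.2-fold higher number from compound 2 to compound 3 (0.08 log units; within the scatter), with the range held wide.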

Compound 3, dose for half-maximal effect: 6.8 mg/kg
Estimate against measurement, compound 3: 1.2-fold (0.07 log units) above; the range from low to high includes it.
By their numbers in this assay, from the lowest: compounds 1, 2 and 3 (each within the scatter of the next).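

In this assay, inverting the stereocentre at the saturated chain carbon gives a 1.0-fold higher number from compound 2 to compound 3 (0.01 log units; within the scatter), so with the isobutyl chain this read-out does not separate the two configurations as drawn. For the compounds shown here, the earlier step concerned only the side chain, so this is the first reading on configuration at this position, and it too lies within the scatter. The pair isolates this single stereo element, with no other structural difference to account for: the fact that compounds 2 and 3 differ only in the configuration as drawn

The compounds shown leave open whether the two configurations also match with the isopropyl chain of compound 1, or with a longer chain or a benzyl group on that carbon. Also open, as far as these compounds go, is whether a carboxylic acid there would leave the configuration equally silent in this assay.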